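Trifluoromethyl in place of 4-chlorophenyl in compound 1

A few compounds are considered here, and "the series" means these few. Any claim that something is new, unique, unknown or untested is made for them only; others in the source may bear on it.

Compound 1 `CC(=O)c1ccc(NC(=O)Cn2nc(-c3ccc(Cl)cc3)nc2N)cc1` at 22% 
Compound 2 `C/C(=N\O)c1ccc(NC(=O)Cn2nc(-c3ccc(Cl)cc3)nc2N)cc1` at 27.4% 
Compound 3 `CC(=O)c1ccc(NC(=O)Cn2nc(C(F)(F)F)nc2N)cc1` not yet measured

Both values come from a functional assay on SK-OV-3 cells (Homo sapiens) for inhibition, read by sulforhodamine B assay, with a stated time of 48 h, tested at 10 uM (on this read-out higher numbers stand for more inhibition of growth at the one concentration tested and lower numbers for less inhibition of growth), and lie within the scatter of each other, so compound 1 is not set apart from compound 2 in this small set. The change under review is trifluoromethyl in place of 4-chlorophenyl on an aromatic carbon and it leaves no ring at that place on the core. Within the data shown here, the only measured step, a number 5.4 percentage points higher from compound 1 to compound 2 (within the scatter), sits at a different place, and no measured compound varies the group that is exchanged here. That step therefore gives a rough scale of size and no direction. A lower number is tentatively expected, as the group that enters is the smaller one, though this rests on no measured comparison. Compound 1 at 22% leaves limited room for a fall, so the expected drop is modest and may not exceed the scatter. The estimated step is a number 8 percentage points lower from compound 1 to compound 3 (within the scatter) with wide uncertainty. For compound 3 the expected value is 14% within an estimated range from 2% to 30% in this assay once measured.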

Compound 3, percent growth inhibition at one concentration: 7.02%
Compound 3: the middle estimate sits 7 percentage points above what was measured; low and high end bracket the measured number.
By their numbers in this assay, from the lowest: compound 3; then compounds 1 and 2 (each within the scatter of the next).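

In this assay, among these compounds, trifluoromethyl in place of 4-chlorophenyl, on the aromatic carbon between two ring nitrogen atoms, gives a number 15 percentage points lower from compound 1 to compound 3 (beyond the scatter) and is the first step in this set printed as beyond the scatter. The earlier step, made at another place on the molecule, did not separate two compounds, whereas this exchange shows that the group at this position can shift growth inhibition at the one concentration tested. The change removes a six-membered aromatic ring of carbon only and its chlorine together, so this single pair cannot assign the lower number to either loss, and nothing measured on these compounds explains the step.

The compounds shown leave open whether the aromatic ring alone carries the higher number, which an unsubstituted phenyl, a 4-fluorophenyl or a cyclohexyl at this position would help to separate from the role of the chlorine. Also open, as far as these compounds go, is whether a plain methyl or an amine at this place would give a number like that of compound 3, and whether the same exchange on compound 2 would produce a step of similar size.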